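Notes on a side-chain change in the series

This account rests on a few compounds, and the source may have more. Where it says the series, first, only, none or still open, it means among the compounds named here.

Measured so far in a physicochemical assay for solubility, in phosphate buffer, with a stated time of 24 h, at pH 7.4 (a lower number here means a less soluble compound, a higher number a more soluble compound), for two compounds:
compound 1 `O=Cc1c(-c2nc(NCCCCN3CCCC3)c3ccccc3n2)[nH]c2ccccc12` gives 15.1 ug/mL
compound 2 `CCN(CC)CCCCNc1nc(-c2[nH]c3ccc(OC)cc3c2C=O)nc2ccccc12` gives 65.9 ug/mL

Compound 2 holds the higher of the two numbers, and its gap to compound 1 lies beyond the usual scatter. Among the compounds with values here, these two compounds differ in more than one place, so no measured pair isolates a single change. Compound 3 `COc1ccc2[nH]c(-c3nc(NCCN4CCCC4)c4ccccc4n3)c(C=O)c2c1` differs from compound 2 in one place, through pyrrolidin-1-yl in place of 2-(diethylamino)ethyl on a saturated chain carbon, two bonds along the chain from a nitrogen on an aromatic ring on a saturated chain carbon, two bonds along the chain from a nitrogen on an aromatic ring. The same difference also reads as 4-(diethylamino)butyl to 2-(pyrrolidin-1-yl)ethyl. Within the data shown here, the expectation leans weakly on compound 1 at 15.1 ug/mL as the only measured compound with pyrrolidin-1-yl. The estimated step of a 1.9-fold lower number from compound 2 to compound 3 (0.27 log units; within the scatter) is a modest fall in this assay and is expected to stay within the scatter. Expected for compound 3 is 35 ug/mL in an estimated range of 10 ug/mL to 110 ug/mL for now.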

Compound 3, solubility: 56.4 ug/mL
Beside the measured number, compound 3's estimate is 1.6-fold (0.21 log units) below it, and the stated range covers the measured number.
By their numbers in this assay, from the lowest: compound 1; then compounds 3 and 2 (each within the scatter of the next).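

In this assay, within the data shown here, the first pair that differs in one place gives a 1.2-fold lower number from compound 2 to compound 3 (0.07 log units; within the scatter) for pyrrolidin-1-yl in place of 2-(diethylamino)ethyl on a saturated chain carbon, two bonds along the chain from a nitrogen on an aromatic ring. At this place, then, a group of 7 heavy atoms with no ring can give way to one of 5 heavy atoms with a five-membered non-aromatic ring without a step beyond the scatter. Nothing at hand says why the number holds across this change.

Compound 1 still differs from both compound 2 and compound 3 in more than one place, so its number cannot be tied to any single change. On these data alone, whether a piperidine or morpholine end, or a longer chain carrying pyrrolidin-1-yl, would also stay within the scatter remains open.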